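Replacing an Aryl Amide with an Isoxazole Amide

The source may report more compounds than this note shows. Statements on the series, on what has been measured and on what is new or still open speak of the compounds shown alone.

compound 1: `CC(=O)Nc1cccc(NC(=O)COc2ccc3c(=O)ccoc3c2)c1` — 136 nM
compound 2: `CCCc1ccc(C(=O)Nc2cccc(NC(=O)COc3ccc4c(=O)ccoc4c3)c2)cc1` — 14 nM
compound 3: `N#Cc1ccc(C(=O)Nc2cccc(NC(=O)COc3ccc4c(=O)ccoc4c3)c2)cc1` — 15 nM

Of the compounds shown here, three sharing one core have been measured in an assay on isolated protein for inhibition of Rho-associated protein kinase 2 (Homo sapiens), read by scintillation counting, radiometric assay and 33P incorporation, with a stated time of 40 min, in the presence of a further agent that is not named here; a lower number here means a stronger inhibitor, a higher number a weaker inhibitor. Compound 1, the simple acetamide, gives 136 nM. Compound 2 gives 14 nM and compound 3 gives 15 nM. Compound 3 thus holds the second highest of the three numbers: its nearest neighbour is compound 2, the difference being a 1.1-fold higher number from compound 2 to compound 3 (0.03 log units; within the scatter), and its furthest is compound 1, with a 9.1-fold lower number from compound 1 to compound 3 (0.96 log units; beyond the scatter).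

Compound 4 `CC(C)(C)c1cc(C(=O)Nc2cccc(NC(=O)COc3ccc4c(=O)ccoc4c3)c2)no1` differs from compound 3 in one place: 5-(tert-butyl)-1,2-oxazol-3-yl in place of 4-cyanophenyl on a carbonyl carbon. For the measured compounds named here, two measured steps bear on this change. Both a 9.7-fold lower number from compound 1 to compound 2 (0.99 log units; beyond the scatter) and a 9.1-fold lower number from compound 1 to compound 3 (0.96 log units; beyond the scatter) show that an aromatic ring on the carbonyl carbon, in place of methyl, brought a similar gain whichever substituent the ring carried, and a 1.1-fold higher number from compound 2 to compound 3 (0.03 log units; within the scatter) shows that exchanging one such substituent for another left the number unchanged within the scatter. Going by the values given here, no measured step, however, involves a five-membered ring with hetero atoms, so the present change is less closely anchored. On this basis a step of no more than about the scatter is expected in this assay, leaning if anything toward a slightly higher number. Compound 4 is therefore expected to give about 25 nM, within 8 nM to 80 nM. That estimate corresponds to an expected step of a 1.7-fold higher number from compound 3 to compound 4 (0.22 log units; within the scatter).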

Compound 4, half-maximal inhibitory concentration: 5 nM
The estimate for compound 4 lay 5.0-fold (0.70 log units) above the measured number; the measured number lies below the stated range.
By their numbers in this assay, from the lowest: compound 4; then compounds 2 and 3 (each within the scatter of the next); then compound 1.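

In this assay, for the compounds shown here, the earlier compounds showed only that two differently substituted phenyl rings on this carbonyl carbon gave the same number within the scatter, whereas 5-(tert-butyl)-1,2-oxazol-3-yl shows that the number can still move at this place, with a 3.0-fold lower number from compound 3 to compound 4 (0.48 log units; beyond the scatter) and a 2.8-fold lower number from compound 2 to compound 4 (0.45 log units; beyond the scatter) beyond it. Going by these compounds alone, a five-membered aromatic ring with 2 hetero atoms is thus accepted here, and against the methyl of the acetamide the change gives a 27-fold lower number from compound 1 to compound 4 (1.43 log units; beyond the scatter) and the only step printed as large, leaving compound 4 with the lowest number of the four. No measurement at hand accounts for this gain or assigns it to the ring or to the tert-butyl group.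

The compounds shown do not separate those two parts, since neither the 1,2-oxazole ring without its tert-butyl group nor a tert-butyl group on a phenyl ring appears among them. Also open, as far as these compounds go, is how an amine, a carboxylic acid or a longer chain in place of the tert-butyl group would read in this assay.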